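Cyclohexyl for octyl at the diene carbon

The source may hold more compounds than are shown below. What is called first, only, known or untested is meant among the compounds shown, and "the series" means these compounds.

Measured compounds:
Compound 1, `CC[C@H](CCCc1cccnc1)NC(=O)/C=C/C=C(c1ccc(OC)cc1)c1ccc(OC)cc1`, gives 0.16 mg/kg.
Compound 2, `CCCCCCCC/C(=C\C=C\C(=O)N[C@H](C)CCCc1cccnc1)c1ccc(OC)cc1`, gives 0.1 mg/kg.
Compound 3, `O=C(/C=C/C=C(c1ccc(Cl)cc1)c1ccc(Cl)cc1)NCCCCc1cccnc1`, gives 0.18 mg/kg.

All three values come from a functional assay with platelet-activating factor receptor (Cavia porcellus) as the target; a lower number here means that less compound is needed, a higher number that more compound is needed for the effect. Compound 2 holds the lowest of the three numbers, but its gap to compound 1 and its gap to compound 3 both lie within the usual scatter of repeated measurements, so none of the three can be told apart from the others with confidence. The three compounds share a core in which an amide-linked diene carries a pyridine-bearing chain on one side; they differ in what the diene carbon bound to the aromatic carbon carries, and in the substituents on the aromatic rings.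

Compound 4, `COc1ccc(/C(=C/C=C/C(=O)N[C@H](C)CCCc2cccnc2)C2CCCCC2)cc1`, has not yet been measured. It differs from compound 2 in one place: cyclohexyl in place of octyl on a double-bonded chain carbon bound to an aromatic carbon and a double-bonded chain carbon. Among the measured compounds shown here, no measured pair in this set isolates that kind of change, so the step from compound 2 to compound 4 cannot be read off from data; it can only be guessed. Since the three measured compounds, with rather different groups at that position, all sit within the scatter of one another, the expected step of a 1.5-fold higher number from compound 2 to compound 4 (0.18 log units; within the scatter) is none beyond the scatter, in no particular direction. Compound 4 is therefore estimated at 0.15 mg/kg, with a range from 0.05 mg/kg to 0.5 mg/kg.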

Compound 4, dose for 50% inhibition: 0.21 mg/kg
Compound 4: middle estimate off by 1.4-fold (0.15 log units), on the low side; low and high end bracket the measured number.
By their numbers in this assay, from the lowest: compounds 2, 1, 3 and 4 (each within the scatter of the next, the first and the last beyond it).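

Among the compounds shown here, for the first time, a single change at this position can be read on its own: in this assay the step is a 2.1-fold higher number from compound 2 to compound 4 (0.32 log units; beyond the scatter) when cyclohexyl takes the place of octyl on a double-bonded chain carbon bound to an aromatic carbon and a double-bonded chain carbon. The earlier compounds shown here differ from one another in more than one place, so they could not show that this group alone moves the number, although the step here is modest and only just passes the usual scatter. The change also does two things at once, replacing an open chain with a ring and lowering the count of heavy atoms, and this one step cannot separate those two differences.

Going by these compounds, whether a shorter open chain such as butyl, or an aromatic phenyl ring, would give a number closer to that of octyl or of cyclohexyl at this carbon remains open, as does whether the same step would hold with a different chain on the amide nitrogen. No separate measurement on these compounds bears on why the number moved.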